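The source may hold more compounds than are shown below. What is called first, only, known or untested is meant among the compounds shown, and "the series" means these compounds.

Working notes on a carbamate series measured in a physicochemical assay for lipophilicity; on this read-out lower numbers stand for lower lipophilicity and higher numbers for higher lipophilicity. Compound 1 `CCCCCCCNC(=O)Oc1ccc(Cl)cc1C(=O)Nc1cccc(Cl)c1` gives 5.94 in this assay. Compound 2 `CCCCCCCCNC(=O)Oc1ccc(Cl)cc1C(=O)Nc1cccc(Cl)c1` gives 6.36. The change between them, (methyl in place of hydrogen on a saturated chain carbon, seven bonds along the chain from an amide-type nitrogen), produced a number 0.42 log units higher from compound 1 to compound 2 (beyond the scatter). Compound 3 `CCCCCCCCCCNC(=O)Oc1ccc(Cl)cc1C(=O)Nc1ccc(Cl)c(Cl)c1` gives 7.77, the highest of the three numbers, and the difference between its core and the core of compound 1 is not broken down here. Compound 4 `CCCCCCCCCCCNC(=O)Oc1ccc(Cl)cc1C(=O)Nc1ccc(Cl)c(Cl)c1` is not yet measured. It differs from compound 3 by methyl in place of hydrogen on a saturated chain carbon, ten or more bonds along the chain from an amide-type nitrogen, the same kind of change as that from compound 1 to compound 2, though at a different place along the chain. Among the compounds with values here, for compound 4 a step of a number 0.43 log units higher from compound 3 to compound 4 (beyond the scatter) is expected, because a number 0.42 log units higher from compound 1 to compound 2 (beyond the scatter) was the step that the one measured change of this kind gave. Compound 4 is therefore estimated at 8.2, within 7.8 to 8.6.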

Compound 4, partition coefficient: 8.17
Beside the measured number, compound 4's estimate is 0.03 log units above it, within the range that was stated.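

In this assay, methyl in place of hydrogen gave a number 0.40 log units higher from compound 3 to compound 4 (beyond the scatter), close in size to a number 0.42 log units higher from compound 1 to compound 2 (beyond the scatter), despite a different core and a different place along the chain. The step therefore carried over between these two cores, but two pairs do not show that it would hold on any other core, or at any other place along the chain. No available evidence explains why the two steps are alike.

Still open, going by these compounds, is whether a step of this size would persist in a longer chain, or in a chain carrying an amine or a carboxylic acid. The compounds shown also leave open how the same change would read outside this assay.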